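Removing a Carbamoyl Group on Two Different Amide Cores

This account rests on a few compounds, and the source may have more. Where it says the series, first, only, none or still open, it means among the compounds named here.

Compound 1 `NC(=O)c1cccc(NC(=O)c2cc3cc([N+](=O)[O-])ccc3o2)c1` and compound 2 `O=C(Nc1ccccc1)c1cc2cc([N+](=O)[O-])ccc2o1` share one core, while compound 3 `NC(=O)c1cccc(NC(=O)c2cnc3ccccc3c2)c1` and compound 4 `O=C(Nc1ccccc1)c1cnc2ccccc2c1` share another; how the two cores differ is not broken down here. In a physicochemical assay for solubility (a higher number here means a more soluble compound, a lower number a less soluble compound), compound 1 gives 20 ug/mL. In the same assay compound 2 gives 25 ug/mL. The change between the two, (hydrogen in place of carbamoyl on an aromatic carbon), produced a 1.3-fold higher number from compound 1 to compound 2 (0.10 log units; within the scatter). Compound 3 gives only a limit of this assay, < 5 ug/mL, and not a number. That limit is the limit of < 5 ug/mL in this assay, at which 1 of the 3 values shown sits.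

Compound 4 has not yet been measured in this assay. It differs from compound 3 by hydrogen in place of carbamoyl on an aromatic carbon, and the place line reads the same, word for word, as for the change from compound 1 to compound 2, so it is the same change made on a second core. Going by the values given here, the only measured example of this change on this read-out is a 1.3-fold higher number from compound 1 to compound 2 (0.10 log units; within the scatter), and the expected step on the second core is a step that the limit leaves unreadable from compound 3 to compound 4, because the one measured instance gave a 1.3-fold higher number from compound 1 to compound 2 (0.10 log units; within the scatter). Since compound 3 itself sits at a limit, it is quite possible that compound 4 will also return only a limit rather than a number. Compound 4 is therefore expected to give about 4 ug/mL in this assay, with a likely range from 1 ug/mL to 12 ug/mL.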

Compound 4, solubility: 5 ug/mL
Compound 4: the middle estimate sits 1.3-fold (0.10 log units) below what was measured, and the stated range covers the measured number.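

In this assay the loss of carbamoyl on the second core gives a number no lower from compound 3 to compound 4 (the limit leaves the size open), so the change did not lower the number on this core, and that sits alongside the first core, where the same change gave a 1.3-fold higher number from compound 1 to compound 2 (0.10 log units; within the scatter). Compound 3 gives only a limit of the assay and not a number, < 5 ug/mL. The two cores therefore share no contradiction in direction, but this does not show that the change carries over with the same size, and the pair on the second core cannot be set against the pair on the first, because the step from the second core rests on a limit: the limit of < 5 ug/mL in this assay, at which 1 of the 4 values shown sits.

On these data alone, whether an amine, a carboxylic acid or a longer chain in place of carbamoyl on that aromatic carbon would move the read-out on either core remains open. It also remains open whether replacing carbamoyl with hydrogen would behave in the same way on any core beyond these two, as the compounds shown cover only this one change on two cores.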